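Pyridin-4-yl in place of 2-phenylethenyl on the carbonyl

A few compounds are considered here, and "the series" means these few. Any claim that something is new, unique, unknown or untested is made for them only; others in the source may bear on it.

- compound 1 `CN(C)CCNc1cc2c(cn1)cc(NC(=O)/C=C/c1ccccc1)c(=O)n2C`: 12100 nM
- compound 2 `CN(C)CCNc1cc2c(cn1)cc(NC(=O)c1cccc(-c3ccccc3)c1)c(=O)n2C`: 1680 nM

In a functional assay on MDA-MB-468 cells (Homo sapiens) for antiproliferative activity, read by MTT assay, with a stated time of 48 h (a lower number here means a stronger inhibitor, a higher number a weaker inhibitor), compound 1 gives 12100 nM, the higher of the two numbers, and compound 2 gives 1680 nM, lower by more than the scatter. Compound 3 `CN(C)CCNc1cc2c(cn1)cc(NC(=O)c1ccncc1)c(=O)n2C` carries pyridin-4-yl in place of 2-phenylethenyl on a carbonyl carbon. For the measured compounds named here, no measured pair shows this kind of change, so the expectation is only loose: no step beyond the scatter is expected in this assay. The expected step is a 1.2-fold lower number from compound 1 to compound 3 (0.08 log units; within the scatter). For compound 3 the estimated value is 10000 nM, with an expected range of 3500 nM to 30000 nM.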

Compound 3, half-maximal inhibitory concentration: 8360 nM
Beside the measured number, compound 3's estimate is 1.2-fold (0.08 log units) above it, and the stated range covers the measured number.
By their numbers in this assay, from the lowest: compound 2; then compounds 3 and 1 (each within the scatter of the next).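

On the carbonyl carbon, pyridin-4-yl in place of 2-phenylethenyl gives a 1.4-fold lower number from compound 1 to compound 3 (0.16 log units; within the scatter) in this assay. This first measured step at this position shows that the exchange, which removes the double bond outside aromatic rings and adds a ring nitrogen, moves the number no further than the scatter. No measurement at hand accounts for this result. Left open is how an amine or a carboxylic acid on the pyridin-4-yl ring, or a saturated alkyl chain in its place on the carbonyl carbon, would read in this assay.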